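A few compounds are considered here, and "the series" means these few. Any claim that something is new, unique, unknown or untested is made for them only; others in the source may bear on it.

Compound 1 `CCOC(=O)c1c(C)nc(-c2cccc(C#N)c2)n1OCC(N)=O` carries carbamoyl on a saturated chain carbon bound to an oxygen on an aromatic ring. In a functional assay on a cell-free system (plasma, Oryctolagus cuniculus) for inhibition, with stated times of 5 min, 1 min and 6 min (on this read-out lower numbers stand for stronger inhibition and higher numbers for weaker inhibition), compound 1 gives > 30000 nM, which is a limit of the assay and not a number. Compound 1 thus stands at the limit of > 30000 nM in this assay, at which 1 of the 2 values shown sits. Compound 2 `CCOC(=O)c1c(C)nc(-c2cccc(C#N)c2)n1OCc1ccc(F)cc1` is the 4-fluorophenyl counterpart; in this assay compound 2 gives 5880 nM. For the measured compounds named here, the only measured step runs an at least 5.1-fold lower number from compound 1 to compound 2 (0.70 log units; beyond the scatter), and its size is known only as a lower bound. Compound 3 `CCOC(=O)c1c(C)nc(-c2cccc(C#N)c2)n1OCc1ccccc1C#N` is the next variation: 2-cyanophenyl in place of carbamoyl on a saturated chain carbon bound to an oxygen on an aromatic ring. The measured step of an at least 5.1-fold lower number from compound 1 to compound 2 (0.70 log units; beyond the scatter) bears directly on it, being the same kind of replacement of carbamoyl by a substituted phenyl at the same place. A step of comparable size, towards stronger inhibition, is therefore expected in this assay, meaning an at least 6.0-fold lower number from compound 1 to compound 3 (0.77 log units; beyond the scatter). Compound 3 is estimated at 5000 nM in this assay, with a range from 1500 nM to 20000 nM.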

Compound 3, half-maximal inhibitory concentration: 9380 nM
Estimate against measurement, compound 3: 1.9-fold (0.27 log units) below, and the stated range covers the measured number.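

In this assay, a second substituted phenyl in place of carbamoyl gives a step in the same direction as the first, an at least 3.1-fold lower number from compound 1 to compound 3 (0.50 log units; beyond the scatter), so the direction at this place no longer rests on 4-fluorophenyl alone. The exchange of 4-fluorophenyl for 2-cyanophenyl gives a 1.6-fold higher number from compound 2 to compound 3 (0.20 log units; within the scatter), so these two groups are not separated in this read-out, even though the substituent and its place on the phenyl ring both differ. Compound 1 remains a limit of the assay and not a number, and both steps from it are known only as lower bounds: the limit of > 30000 nM in this assay, at which 1 of the 3 values shown sits.

Going by these compounds, what an unsubstituted phenyl, a carboxylic acid or a longer chain would give at this place remains open. Also open, on these data alone, is whether the aromatic ring or the loss of the amide hydrogen matters more, as each replacement changes both together.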